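A few compounds are considered here, and "the series" means these few. Any claim that something is new, unique, unknown or untested is made for them only; others in the source may bear on it.

In a functional assay on KBVIN cells (Homo sapiens) for antiproliferative activity, read by sulforhodamine B assay, with a stated time of 3 days (a higher number here means that more compound is needed for the effect, a lower number that less compound is needed), compound 1 `CCC1=C(O)c2c(oc(-c3ccc(CC)cc3)cc2=O)C(CC)(CC)C1=O` gives 0.07 uM, compound 2 `CCOc1ccc(-c2cc(=O)c3c(o2)C(CC)(CC)C(=O)C(CC)=C3O)cc1` gives 7.54 uM, and compound 3 `CCC1=C(O)c2c(oc(-c3ccc(OC)cc3C)cc2=O)C(CC)(CC)C1=O` gives 2.62 uM, the second highest of the three numbers. Compound 4 `CCC1=C(O)c2c(oc(-c3cc(C)c(O)c(C)c3)cc2=O)C(CC)(CC)C1=O` is unmeasured and carries 4-hydroxy-3,5-dimethylphenyl in place of the 4-methoxy-2-methylphenyl of compound 3 (4-hydroxy-3,5-dimethylphenyl in place of 4-methoxy-2-methylphenyl on an aromatic carbon). Two measured steps change the group at this place: a 37-fold higher number from compound 1 to compound 3 (1.57 log units; beyond the scatter) and a 2.9-fold lower number from compound 2 to compound 3 (0.46 log units; beyond the scatter). Among the compounds with values here, no measured compound carries a hydroxy group there, so the direction is poorly defined, and a modest drop in this assay is expected, with a large step in either direction not excluded. The expected change is a 2.2-fold lower number from compound 3 to compound 4 (0.34 log units; beyond the scatter). Compound 4 is estimated at 1.2 uM, with an expected range of 0.2 uM to 7 uM.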

Compound 4, concentration for half-maximal effect: 8.9 uM
The estimate for compound 4 lay 7.4-fold (0.87 log units) below the measured number; the whole stated range lies below it.
By their numbers in this assay, from the lowest: compound 1; then compound 3; then compounds 2 and 4 (each within the scatter of the next).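

In this assay, a hydroxy-bearing group at this place brings no gain: 4-hydroxy-3,5-dimethylphenyl gives a 3.4-fold higher number from compound 3 to compound 4 (0.53 log units; beyond the scatter) and a 130-fold higher number from compound 1 to compound 4 (2.10 log units; beyond the scatter). It also stands level with 4-ethoxyphenyl, at a 1.2-fold higher number from compound 2 to compound 4 (0.07 log units; within the scatter), so 4-ethylphenyl remains alone at the low end of the four numbers. No available evidence explains these differences.

From the compounds shown here alone, the hydroxy group and the rearranged methyl groups change together here, so their separate contributions stay open. Also open, going by these compounds, is how an amine, a carboxylic acid or a propyl chain on this phenyl ring would read out.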